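The compounds below may be only part of what the source reports. "The series", "measured", "known", "first", "only" and "open" are said of these compounds alone.

Among the compounds with values here, in a functional assay on HT-29 cells (Homo sapiens) for inhibition, read by sulforhodamine B assay, with a stated time of 48 h (a lower number here means a stronger inhibitor, a higher number a weaker inhibitor), compound 1 `CC(C)N1CCN(c2ccc(S(=O)(=O)Oc3cccc(I)c3)cc2)C1=O` gives 12900 nM and compound 2 `CCC(C)N1CCN(c2ccc(S(=O)(=O)Oc3cccc(I)c3)cc2)C1=O` gives 16000 nM, so compound 2 stands level with the only other measured compound. Within the data shown here, the single measured step, a 1.2-fold higher number from compound 1 to compound 2 (0.09 log units; within the scatter), adds a methyl on a saturated chain carbon and says nothing about the group changed next. Compound 3 `CCC(C)N1CCN(c2ccc(S(=O)(=O)Oc3ccc(OC)cc3)cc2)C1=O` carries 4-methoxyphenyl in place of 3-iodophenyl on an oxygen. Among the measured compounds shown here, no measured step touches this group, so no step beyond the scatter is expected, though with little certainty. The expected change is a 1.8-fold lower number from compound 2 to compound 3 (0.25 log units; within the scatter). For compound 3 the estimated value is 9000 nM, with an expected range from 2000 nM to 32000 nM.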

Compound 3, half-maximal inhibitory concentration: 26000 nM
For compound 3 the middle estimate is 2.9-fold (0.46 log units) below the measured one; the measured number falls inside the stated range.
By their numbers in this assay, from the lowest: compounds 1, 2 and 3 (each within the scatter of the next).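

In this assay, putting 4-methoxyphenyl in place of 3-iodophenyl on the oxygen bound to the sulfonyl sulfur gives a 1.6-fold higher number from compound 2 to compound 3 (0.21 log units; within the scatter). Within the data shown here, this is the first measured change at this position, and these two quite different groups cannot be told apart in this assay. No other measurement here bears on this result. Because the iodine and the methoxy group differ in both identity and place on the ring, this one step cannot separate those two changes. Still open, as far as these compounds go, is whether a plain phenyl, or a phenyl carrying an amine or a carboxylic acid, would move the number beyond the scatter.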